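Changing One Ring on an Inactive Pair

The compounds below may be only part of what the source reports. "The series", "measured", "known", "first", "only" and "open" are said of these compounds alone.

Compound 1 `CC(=O)c1ccc(-c2ccc3c(C(=O)Nc4cccc(F)c4)cc(=O)[nH]c3c2)cc1` and compound 2 `Cc1ccc(-c2ccc3c(C(=O)Nc4cccc(F)c4)cc(=O)[nH]c3c2)cc1` share a core and differ by methyl in place of acetyl on an aromatic carbon. In a functional assay on KYSE-410 cells (Homo sapiens) for antiproliferative activity, read by MTT assay, with a stated time of 72 h (a lower number here means a stronger inhibitor, a higher number a weaker inhibitor), compound 1 gives > 20000 nM, which is a limit of the assay and not a number. In this assay, compound 2 gives > 20000 nM, which is also a limit. Both compounds stand together here: the limit of > 20000 nM in this assay, at which 2 of the 2 values shown sit.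

Compound 3 `O=C(Nc1cccc(F)c1)c1cc(=O)[nH]c2cc(-c3ccc(F)nc3)ccc12` carries 6-fluoropyridin-3-yl in place of 4-methylphenyl on an aromatic carbon. Within the data shown here, the only measured step, a step that the two limits leave unreadable from compound 1 to compound 2, offers no size to carry over, so no step beyond the scatter is expected in this assay, and no direction can be favoured. The estimated change is a step that the limit leaves unreadable from compound 2 to compound 3. For compound 3 the expected value is 25000 nM, with an estimated range from 10000 nM to 60000 nM.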

Compound 3, half-maximal inhibitory concentration: > 20000 nM
Compound 3 ended at the assay's limit (the forecaster's own chance of this, stated with the estimate: 80%); the middle value is on the limit's open side.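

In this assay compound 3 gives > 20000 nM and this is a limit of the assay, not a number. Among these compounds, no step among compound 1, compound 2 and compound 3 can be read. The compounds shown leave open how the 4-acetylphenyl, 4-methylphenyl and 6-fluoropyridin-3-yl groups rank against one another, and whether any of them can give a true number in this assay at all.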